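This account rests on a few compounds, and the source may have more. Where it says the series, first, only, none or still open, it means among the compounds named here.

Measured so far in a functional assay on CHO-K1 cells for antagonist activity at adenosine receptor A1 (Homo sapiens), read by a beta-galactosidase reporter and cAMP accumulation, with stated times of 15 min and 6 h; on this read-out higher numbers stand for weaker inhibition and lower numbers for stronger inhibition:
compound 1, `CC(C)c1ccc(-c2nc(N)c3cc(Cc4ccccc4)sc3n2)o1`, gives 283 nM;
compound 2, `N#Cc1ccc(-c2nc(N)c3cc(Cc4ccccc4)sc3n2)o1`, gives 3160 nM;
compound 3, `Nc1nc(-c2ccccc2)nc2sc(Cc3ccccc3)cc12`, gives 151 nM.

Compound 3 sits at the low end of these three numbers, although a 1.9-fold lower number from compound 1 to compound 3 (0.27 log units; within the scatter) means compound 3 and compound 1 cannot be told apart, whereas a 21-fold lower number from compound 2 to compound 3 (1.32 log units; beyond the scatter) is a clear gap. Compound 4, `Nc1nc(-c2ccccn2)nc2sc(Cc3ccccc3)cc12`, differs from compound 3 by pyridin-2-yl in place of phenyl on an aromatic carbon. Within the data shown here, no measured step swaps phenyl for pyridin-2-yl. The steps seen change the group at this same position in other ways: an 11-fold higher number from compound 1 to compound 2 (1.05 log units; beyond the scatter) was large, while a 1.9-fold lower number from compound 1 to compound 3 (0.27 log units; within the scatter) was small. Since a six-membered aromatic ring with one hetero atom replaces a ring of the same size, the expected step is a 1.3-fold higher number from compound 3 to compound 4 (0.12 log units; within the scatter). Compound 4 is therefore estimated at 200 nM, with a range from 60 nM to 700 nM.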

Compound 4, inhibition constant: 3710 nM
Beside the measured number, compound 4's estimate is 19-fold (1.27 log units) below it; the whole stated range lies below it.
By their numbers in this assay, from the lowest: compounds 3 and 1 (each within the scatter of the next); then compounds 2 and 4 (each within the scatter of the next).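

In this assay, one ring nitrogen at this position proved a large change, with pyridin-2-yl replacing phenyl (a 25-fold higher number from compound 3 to compound 4 (1.39 log units; beyond the scatter)) and replacing 5-isopropylfuran-2-yl (a 13-fold higher number from compound 1 to compound 4 (1.12 log units; beyond the scatter)), whereas compound 3 and compound 1 could not be told apart. Replacing 5-cyanofuran-2-yl gave no clear shift (a 1.2-fold higher number from compound 2 to compound 4 (0.07 log units; within the scatter)), so ring size alone does not keep the number low. Nothing available explains this difference.

Whether the location of the ring nitrogen matters remains open, as pyridin-3-yl and pyridin-4-yl are absent from the compounds shown.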